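Replacing the 2-methoxyphenyl Group of Compound 2

The source may report more compounds than this note shows. Statements on the series, on what has been measured and on what is new or still open speak of the compounds shown alone.

Among the measured compounds shown here, in a functional assay on MCF7 cells (Homo sapiens) for antiproliferative activity, read by MTT assay (on this read-out higher numbers stand for weaker inhibition and lower numbers for stronger inhibition), compound 1 (`COc1cc2c(Oc3ccc(NC(=O)Nc4ccccc4F)cc3)ccnc2cc1OCCCCCCC(=O)NO`) gives 660 nM, while compound 2 (`COc1ccccc1NC(=O)Nc1ccc(Oc2ccnc3cc(OCCCCCCC(=O)NO)c(OC)cc23)cc1`) gives 6280 nM, the higher of the two numbers so far. Compound 3 (`COc1cc2c(Oc3ccc(NC(=O)N/N=C/c4ccc(F)cc4)cc3)ccnc2cc1OCCCCCCC(=O)NO`) remains unmeasured and differs from compound 2 as follows: a group of 9 heavy atoms (7 carbon, 1 nitrogen, 1 fluorine; one six-membered aromatic ring of carbon only) in place of a group of 8 heavy atoms (7 carbon, 1 oxygen; one six-membered aromatic ring of carbon only), on an amide-type nitrogen. For the measured compounds named here, the only measured step, a 9.5-fold higher number from compound 1 to compound 2 (0.98 log units; beyond the scatter), shows that a single swap of fluoro for methoxy on an aromatic carbon can shift the number beyond the scatter. Going by the values given here, no measured step covers a change this large, but with the 2-methoxyphenyl group gone, a move toward lower numbers is expected. The expected size of the move is a 3.5-fold lower number from compound 2 to compound 3 (0.54 log units; beyond the scatter). For compound 3, the estimated value is 1800 nM, with an expected range of 350 nM to 7000 nM.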

Compound 3, half-maximal inhibitory concentration: 1360 nM
Compound 3: middle estimate off by 1.3-fold (0.12 log units), on the high side; low and high end bracket the measured number.
By their numbers in this assay, from the lowest: compound 1; then compound 3; then compound 2.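

In this assay, the amide-type nitrogen accepts a group with a double bond outside the aromatic ring, not only a group like that of compound 1, giving a 4.6-fold lower number from compound 2 to compound 3 (0.66 log units; beyond the scatter). That group still falls short of the fluorine-bearing group of compound 1, with a 2.1-fold higher number from compound 1 to compound 3 (0.31 log units; beyond the scatter), so it recovers only part of the ground lost with the 2-methoxyphenyl group. Nothing available explains either shift. On these data alone, it remains open whether the double bond or the fluorine matters more, and whether a chloro group in place of the fluorine or a saturated carbon link in place of the double bond would move the number.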